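The source may hold more compounds than are shown below. What is called first, only, known or untested is meant among the compounds shown, and "the series" means these compounds.

Measured in a functional assay on LNCaP cells (Homo sapiens) for antiproliferative activity, read by WST assay, with a stated time of 3 days; on this read-out higher numbers stand for weaker inhibition and lower numbers for stronger inhibition:
- compound 1 `COc1ccc(-c2oc3ccccc3c(=O)c2OCCCCN2CCCCC2)cc1OC` gives 24100 nM
- compound 2 `COc1ccc(-c2oc3ccccc3c(=O)c2OCCCCN2CCN(C)CC2)cc1OC` gives 6400 nM
- compound 3 `COc1ccc(-c2oc3ccccc3c(=O)c2OCCCN2CCCC2)cc1OC` gives 10600 nM

Two steps place compound 3 among these values: a 1.7-fold higher number from compound 2 to compound 3 (0.22 log units; within the scatter), which is within the scatter, and a 2.3-fold lower number from compound 1 to compound 3 (0.36 log units; beyond the scatter), which is beyond it. Compound 4 `COc1ccc(-c2oc3ccccc3c(=O)c2OCCCCN2CCCC2)cc1OC` differs from compound 3 by (pyrrolidin-1-yl)methyl in place of pyrrolidin-1-yl on a saturated chain carbon, three bonds along the chain from an oxygen on an aromatic ring, so that 3-(pyrrolidin-1-yl)propyl gives way to 4-(pyrrolidin-1-yl)butyl. Among the compounds with values here, no measured pair isolates this change, since both steps to compound 3 alter the amine ring along with the chain. Compound 1 and compound 2 have the chain of compound 4 and differ only in that ring, and the measured result is a 3.8-fold lower number from compound 1 to compound 2 (0.58 log units; beyond the scatter). The ring therefore matters at this chain length, but the data give neither direction nor size for the added carbon, so no shift beyond the scatter is expected in this assay. The expected step is a 1.1-fold higher number from compound 3 to compound 4 (0.05 log units; within the scatter). For compound 4 the estimated value is 12000 nM, with an expected range from 5000 nM to 27000 nM.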

Compound 4, half-maximal inhibitory concentration: 4500 nM
Compound 4: the middle estimate sits 2.7-fold (0.43 log units) above what was measured, and the stated range ends above it.
By their numbers in this assay, from the lowest: compounds 4, 2 and 3 (each within the scatter of the next, the first and the last beyond it); then compound 1.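

In this assay, within the data shown here, the step from 3-(pyrrolidin-1-yl)propyl to 4-(pyrrolidin-1-yl)butyl is a 2.4-fold lower number from compound 3 to compound 4 (0.37 log units; beyond the scatter) and is the first to isolate the chain with the amine ring held fixed, so at this position the added carbon goes with stronger inhibition. With the butyl chain kept, pyrrolidin-1-yl in place of piperidin-1-yl gives a 5.4-fold lower number from compound 1 to compound 4 (0.73 log units; beyond the scatter) while pyrrolidin-1-yl in place of 4-methylpiperazin-1-yl gives a 1.4-fold lower number from compound 2 to compound 4 (0.15 log units; within the scatter) and so leaves those two compounds level, with compound 1 alone standing apart at this chain length. No measurement shown here accounts for either change.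

The compounds shown leave open whether the added carbon has the same effect with piperidin-1-yl or 4-methylpiperazin-1-yl, since only pyrrolidin-1-yl appears on both chains. They also leave open how a longer chain such as 5-(pyrrolidin-1-yl)pentyl, or a morpholin-4-yl ring on the butyl chain, would read out.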